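This account rests on a few compounds, and the source may have more. Where it says the series, first, only, none or still open, it means among the compounds named here.

Going by the values given here, compound 2 `COc1ccc(C(=O)OC2(C(=O)Nc3ccc([N+](=O)[O-])cc3)CCCCC2)cc1` is one of only two compounds measured so far in a functional assay on HepG2 cells (Homo sapiens) for inhibition, read by MTT assay, with a stated time of 72 h (a higher number here means a weaker inhibitor, a lower number a stronger inhibitor), and there compound 2 gives 57.1 nM. Its companion, compound 1 `Cc1ccc(C(=O)OC2(C(=O)Nc3ccc([N+](=O)[O-])cc3)CCCCC2)cc1`, gives in this assay 61.2 nM. The step of a 1.1-fold lower number from compound 1 to compound 2 (0.03 log units; within the scatter) leaves the two within the scatter of the measurement, so neither can be called the stronger inhibitor. Compound 3 `O=C(OC1(C(=O)Nc2ccc([N+](=O)[O-])cc2)CCCCC1)c1ccc([N+](=O)[O-])cc1` has not yet been measured. It differs from compound 2 in one place: nitro in place of methoxy on an aromatic carbon. Among the compounds with values here, the only measured step, a 1.1-fold lower number from compound 1 to compound 2 (0.03 log units; within the scatter), also exchanged one group for another at that same place and hardly moved the number. That single step is the whole guide here, and it involves a different incoming group, so it bears on the new change only loosely. The step expected in this assay is therefore estimated as a 1.0-fold lower number from compound 2 to compound 3 (0.02 log units; within the scatter), without a direction beyond the scatter, though with a wider margin of doubt. Compound 3 is expected to give 55 nM in this assay, with a plausible range from 18 nM to 170 nM.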

Compound 3, half-maximal inhibitory concentration: 14.1 nM
For compound 3 the middle estimate is 3.9-fold (0.59 log units) above the measured one; the measured number lies below the stated range.
By their numbers in this assay, from the lowest: compound 3; then compounds 2 and 1 (each within the scatter of the next).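

The earlier exchange of methyl for methoxy gave no difference beyond the scatter, so this aromatic carbon, para to a large group, could have seemed indifferent to what it carries. In this assay nitro now gives a clear change, with a 4.0-fold lower number from compound 2 to compound 3 (0.61 log units; beyond the scatter) and a 4.3-fold lower number from compound 1 to compound 3 (0.64 log units; beyond the scatter), so the place does respond to the group it holds, and the two steps agree: compound 3 is the stronger inhibitor against each of the other two compounds, which stay within the scatter of each other. No accompanying measurement offers an explanation of why nitro stands apart from methyl and methoxy.

Three groups at one place cannot show whether nitro is unusual here or simply one of many groups that would give a low number, and an amine, a carboxylic acid, a nitrile or a trifluoromethyl at the same carbon would help to settle that. From the compounds shown here alone, the rest of the core is the same in all three compounds, so it also remains open whether this exchange would give a similar step on a different core.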